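Benzyl for 2-Fluorophenyl on a Triazole Nitrogen

A few compounds are considered here, and "the series" means these few. Any claim that something is new, unique, unknown or untested is made for them only; others in the source may bear on it.

Within the data shown here, compound 1 `CCCCCc1ccc(C#Cc2c(-c3ccc(CCCCC)cc3)oc3nc(=O)n(Cc4cn(-c5ccccc5F)nn4)cc23)cc1` is the only compound with a number in a functional assay on SW-620 cells (Homo sapiens) for antiproliferative activity, read by MTT assay, with a stated time of 72 h (a lower number here means a stronger inhibitor, a higher number a weaker inhibitor), where compound 1 gives 57100 nM. Compound 2 `O=c1c(I)cn(Cc2cn(Cc3ccccc3)nn2)c(=O)n1Cc1cn(Cc2ccccc2)nn1` reaches only the limit of > 100000 nM in this assay, and (the limit of > 100000 nM in this assay, at which 1 of the 2 values shown sits). Compound 3 `CCCCCc1ccc(C#Cc2c(-c3ccc(CCCCC)cc3)oc3nc(=O)n(Cc4cn(Cc5ccccc5)nn4)cc23)cc1` keeps the core of compound 1 and changes one group: benzyl in place of 2-fluorophenyl on an aromatic nitrogen. Among the measured compounds shown here, no measured pair shows the effect of such a change, so no step beyond the scatter is expected in this assay in either direction. Compound 3 is expected to give 60000 nM, between 25000 nM and 150000 nM. The step of a 1.1-fold higher number from compound 1 to compound 3 (0.02 log units; within the scatter) that this estimate means is expected to stay within the scatter.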

Compound 3, half-maximal inhibitory concentration: > 100000 nM
Compound 3: a limit, no number (the forecaster's own chance of this, stated with the estimate: 30%); at least 1.6-fold (0.22 log units) between middle value and limit.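

Benzyl in place of 2-fluorophenyl on this aromatic nitrogen gives the first step measured for the change, an at least 1.7-fold higher number from compound 1 to compound 3 (0.24 log units; that floor lies within the scatter), so its true size stays unknown and the floor alone does not establish a loss. In this assay compound 3 gives > 100000 nM, which is a limit of the assay and not a number. The pair therefore adds a second compound at that limit: the limit of > 100000 nM in this assay, at which 2 of the 3 values shown sit.

Going by these compounds, whether an unsubstituted phenyl or a 2-phenylethyl group on this triazole nitrogen would give a number in this assay remains open.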